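Benzoyl in place of acetyl on a diflunisal-type amide

The source may hold more compounds than are shown below. What is called first, only, known or untested is meant among the compounds shown, and "the series" means these compounds.

Measured compounds:
- compound 1, `CC(=O)Oc1ccc(-c2ccc(F)cc2F)cc1C(=O)Nc1ccccc1C`: 12.3%
- compound 2, `CC(=O)Oc1ccc(-c2ccc(F)cc2F)cc1C(=O)Nc1ccc(Cl)cc1`: 29.9%
- compound 3, `CC(=O)Oc1ccc(-c2ccc(F)cc2F)cc1C(=O)NN1CCOCC1`: 28.5%

These three compounds share a core and differ only in the group on the amide-type nitrogen. In a functional assay on the whole organism (strain Kunming) for inhibition, with Mus musculus as the target, in the writhing test, at a dose of 40 mg/kg by the oral route (a lower number here means less inhibition, a higher number more inhibition at the dose given (going by the name of the read-out)), compound 1 stands lowest of the three. Replacing its 2-methylphenyl by 4-chlorophenyl gave a number 17.6 percentage points higher from compound 1 to compound 2 (beyond the scatter), and replacing it by morpholin-4-yl gave a number 16.2 percentage points higher from compound 1 to compound 3 (beyond the scatter); between compound 2 and compound 3 the step was a number 1.4 percentage points lower from compound 2 to compound 3 (within the scatter).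

Compound 4, `Cc1ccccc1NC(=O)c1cc(-c2ccc(F)cc2F)ccc1OC(=O)c1ccccc1`, keeps the 2-methylphenyl of compound 1 and changes a different place: phenyl in place of methyl on a carbonyl carbon. For the measured compounds named here, none of the measured steps touches this carbonyl carbon; all of them alter the amide-type nitrogen, so nothing measured here tells how much this change can move the read-out. Without a guide, the expected step in this assay is none beyond the scatter, so a number 2.7 percentage points higher from compound 1 to compound 4 (within the scatter) is the estimate. Compound 4 is therefore expected to give about 15%, within a range from 3% to 30%.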

Compound 4, a percentage reported as inhibition, in the whole organism at one dose (the size of the read-out at that dose, not a potency): 20.8%
For compound 4 the middle estimate is 5.8 percentage points below the measured one; measured number inside the range.
By their numbers in this assay, from the lowest: compounds 1, 4, 3 and 2 (each within the scatter of the next, the first and the last beyond it).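

Putting phenyl in place of methyl on the carbonyl carbon, which turns acetyl into benzoyl and acetoxy into benzoyloxy, gave in this assay a number 8.5 percentage points higher from compound 1 to compound 4 (within the scatter). This position therefore takes a six-membered aromatic ring in place of a single methyl with no step beyond the scatter, whereas the two changes on the amide-type nitrogen starting from compound 1 each gave a step beyond it. No measurement available here bears on this result.

On these data alone, it remains open whether the same change would give a similar step with the 4-chlorophenyl of compound 2 or the morpholin-4-yl of compound 3 on the nitrogen. Also open, as far as these compounds go, is how the number would respond to other groups on this carbonyl carbon, such as a longer carbon chain or an amine.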